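Working notes: compound 3 to compound 4

The source may report more compounds than this note shows. Statements on the series, on what has been measured and on what is new or still open speak of the compounds shown alone.

- compound 1 `O=C(NNc1ccc(F)cc1)c1ccc(NS(=O)(=O)c2cnc(O)nc2O)cc1`: > 20000 nM (a limit)
- compound 2 `O=C(NNc1ccccc1F)c1cccc(NS(=O)(=O)c2cnc(O)nc2O)c1`: > 20000 nM (a limit)
- compound 3 `O=C(NNc1ccccc1Cl)c1ccccc1NS(=O)(=O)c1cnc(O)nc1O`: 18900 nM

Within the data shown here, in a functional assay on MDA-MB-231 cells (Homo sapiens) for antiproliferative activity, read by MTT assay, with a stated time of 24 h (a lower number here means a stronger inhibitor, a higher number a weaker inhibitor), compound 3 gives 18900 nM, the only true number so far. The other two entries are limits, not numbers: the limit of > 20000 nM in this assay, at which 2 of the 3 values shown sit.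

Compound 4 `O=C(NNC(=O)c1ccccc1NS(=O)(=O)c1cnc(O)nc1O)c1cccc(Cl)c1` carries (3-chlorophenyl)carbonyl in place of 2-chlorophenyl on an amine nitrogen. Among the measured compounds shown here, no measured pair shows what a change of this kind does. The expectation therefore rests on compound 3 at 18900 nM, and no step beyond the scatter is expected in this assay.

The expected change is a 1.3-fold lower number from compound 3 to compound 4 (0.10 log units; within the scatter).

The estimate for compound 4 is 15000 nM, with an expected range of 5000 nM to 30000 nM.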

Compound 4, half-maximal inhibitory concentration: 4420 nM
Estimate against measurement, compound 4: 3.4-fold (0.53 log units) above, outside the stated range (below it).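

In this assay, among these compounds, replacing 2-chlorophenyl with (3-chlorophenyl)carbonyl on an amine nitrogen gives a 4.3-fold lower number from compound 3 to compound 4 (0.63 log units; beyond the scatter), the first readable evidence that this position responds to change. The step combines the added carbonyl with the change from 2-chlorophenyl to 3-chlorophenyl, and the compounds shown cannot separate the two. Compounds 1 and 2 remain limits, not numbers, and give no further step: the limit of > 20000 nM in this assay, at which 2 of the 4 values shown sit.

From the compounds shown here alone, it remains open whether the carbonyl with 2-chlorophenyl retained would give a similar step. Also open, going by these compounds, is how an amine or a carboxylic acid in place of the chlorine would read.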